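From methyl to (pyridin-4-yl)methyl on the aromatic nitrogen

This account rests on a few compounds, and the source may have more. Where it says the series, first, only, none or still open, it means among the compounds named here.

In a functional assay on MCF7 cells (Homo sapiens) for cytotoxicity (a higher number here means a weaker inhibitor, a lower number a stronger inhibitor), compound 3 `Cc1cc(Nc2nn(C)c(=O)c3ccccc23)n[nH]1` gives > 30000 nM, which is a limit and not a number. In this assay compound 1 `COc1ccc(-n2nc(Nc3cc(C)[nH]n3)c3ccccc3c2=O)cc1` gives 3600 nM and compound 2 `Cc1cc(Nc2nn(-c3ccc(F)cc3)c(=O)c3ccccc23)n[nH]1` gives 1600 nM. Compound 4 `Cc1cc(Nc2nn(Cc3ccncc3)c(=O)c3ccccc23)n[nH]1` differs from compound 3 as pyridin-4-yl in place of hydrogen on a saturated chain carbon bound to an aromatic nitrogen.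

For the measured compounds named here, two steps bear on this: an at least 8.3-fold higher number from compound 1 to compound 3 (0.92 log units; beyond the scatter), and an at least 18-fold higher number from compound 2 to compound 3 (1.27 log units; beyond the scatter). Both put methyl in place of a ring on an aromatic nitrogen, so a ring returning is expected to lower the number. In compound 4 the ring sits on a saturated chain carbon instead, so a smaller move is expected. The expected change is an at least 3.3-fold lower number from compound 3 to compound 4 (0.52 log units; beyond the scatter). Compound 4 is estimated at 9000 nM, with an expected range of 2500 nM to 30000 nM.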

Compound 4, half-maximal inhibitory concentration: > 30000 nM
Compound 4 ended at the assay's limit (the forecaster's own chance of this, stated with the estimate: 30%); middle value at least 3.3-fold (0.52 log units) from the limit.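

In this assay compound 4 gives > 30000 nM, which is a limit of the assay and not a number. A ring on this nitrogen is not enough when it comes as (pyridin-4-yl)methyl: there is an at least 18-fold higher number from compound 2 to compound 4 (1.27 log units; beyond the scatter) and an at least 8.3-fold higher number from compound 1 to compound 4 (0.92 log units; beyond the scatter). The step between compound 3 and compound 4 cannot be read, since both stand at one limit: the limit of > 30000 nM in this assay, at which 2 of the 4 values shown sit.

Whether the pyridin-4-yl ring itself or its saturated chain carbon accounts for this remains open. A benzyl group on the aromatic nitrogen would separate the two.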